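The compounds below may be only part of what the source reports. "The series", "measured", "known", "first", "only" and "open" are said of these compounds alone.

Working notes on the amide series built on the core of compound 3 `CC(C)NC(=O)c1c(NO)cc(-c2ccccc2)oc1=O`. In an ADME assay on Huh-7 cells (Homo sapiens) for cytotoxicity, read by a luciferase reporter and WST assay, with a stated time of 3 days (a lower number here means that less compound is tolerated, a higher number that more compound is tolerated), compound 3 gives > 20000 nM, which is a limit of the assay and not a number. The two other amides measured so far stand at the same place. Compound 1 `O=C(Nc1ccc(F)cc1)c1c(NO)cc(-c2ccccc2)oc1=O` gives > 20000 nM in this assay, again a limit. Compound 2 `CNC(=O)c1c(NO)cc(-c2ccccc2)oc1=O` gives > 20000 nM in this assay, also a limit. With all three values at the limit, the steps between them cannot be read: a step that the two limits leave unreadable from compound 1 to compound 2, a step that the two limits leave unreadable from compound 1 to compound 3 and a step that the two limits leave unreadable from compound 2 to compound 3. For the measured compounds named here, the one thing the measurements do show is the limit of > 20000 nM in this assay, at which 3 of the 3 values shown sit.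

Compound 4 `O=C(NCc1ccccc1)c1c(NO)cc(-c2ccccc2)oc1=O` takes the next step: benzyl in place of isopropyl on an amide-type nitrogen. Going by the values given here, the substituents tried so far on this nitrogen, methyl, isopropyl and 4-fluorophenyl, all left the value at the limit, so none of the measured steps gives a size to carry over. Nothing in these three values speaks for a change beyond the scatter in this assay from this substitution, though none of them can exclude one either. Compound 4 is therefore expected to give 30000 nM, with a range from 12000 nM to 100000 nM. The step this implies is estimated as a step that the limit leaves unreadable from compound 3 to compound 4.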

Compound 4, half-maximal cytotoxic concentration: > 20000 nM
Compound 4: no number, only a limit; the forecaster's own chance of this, stated with the estimate: 80%; the middle value does not contradict the limit.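

In this assay compound 4 gives > 20000 nM, a limit of the assay and not a number. Its steps to compound 1, compound 2 and compound 3 cannot be read, and the measurements still show only one thing: the limit of > 20000 nM in this assay, at which 4 of the 4 values shown sit.

The compounds shown leave open whether any substituent on this amide nitrogen gives a readable value in this assay.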